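The source may report more compounds than this note shows. Statements on the series, on what has been measured and on what is new or still open speak of the compounds shown alone.

Measured compounds in a functional assay on A549 cells (Homo sapiens) for cytotoxicity, read by MTT assay, with a stated time of 72 h; on this read-out higher numbers stand for weaker inhibition and lower numbers for stronger inhibition:
compound 1, `COc1ccc(-c2cc(C(=O)Nc3ccc(Oc4ccnc5[nH]ccc45)cc3)ncn2)cc1`: 4410 nM
compound 2, `O=C(Nc1ccc(Oc2ccnc3[nH]ccc23)cc1)c1cc(-c2ccc(Cl)cc2)ncn1`: 6530 nM
compound 3, `COc1ccc(-c2ccnc(C(=O)Nc3ccc(Oc4ccnc5[nH]ccc45)c(F)c3)n2)cc1`: 5430 nM

Compound 4, `O=C(Nc1ccc(Oc2ccnc3[nH]ccc23)c(F)c1)c1nccc(-c2ccc(Cl)cc2)n1`, has not yet been measured in this assay.

Compounds 1 and 2 differ in one place: chloro in place of methoxy on an aromatic carbon. That change gave a 1.5-fold higher number from compound 1 to compound 2 (0.17 log units; within the scatter). Compounds 1 and 3 differ in more than one place; the difference between the two cores is not broken down here.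

Compound 4 relates to compound 3 as compound 2 relates to compound 1: chloro in place of methoxy on an aromatic carbon. The place is described in the same words for both pairs, so this is the same change, here applied to the core of compound 3. Going by the values given here, the only measured instance of it lies within the scatter, and since the cores are not broken down here, that single step is all that carries over. A step of similar size is expected from compound 3 to compound 4, a 1.4-fold higher number from compound 3 to compound 4 (0.14 log units; within the scatter), because the earlier step of a 1.5-fold higher number from compound 1 to compound 2 (0.17 log units; within the scatter) stayed small. Compound 4 is therefore expected to give about 7500 nM in this assay, most likely between 3500 nM and 16000 nM.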

Compound 4, half-maximal inhibitory concentration: 8940 nM
Compound 4: the middle estimate sits 1.2-fold (0.08 log units) below what was measured; the measured number falls inside the stated range.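

In this assay, chloro in place of methoxy on an aromatic carbon gives a 1.6-fold higher number from compound 3 to compound 4 (0.22 log units; within the scatter), and this step can be set beside the one on the other core: the same change on two cores in this assay, a 1.5-fold higher number (0.17 log units; within the scatter) from compound 1 to compound 2 and a 1.6-fold higher number (0.22 log units; within the scatter) from compound 3 to compound 4, 1.1-fold (0.05 log units) apart, within the scatter of two such steps On these two cores, then, the change from 4-methoxyphenyl to 4-chlorophenyl carries over with no difference that can be told from the scatter, and on neither core does it lie beyond the scatter. This does not show that the step is independent of the core in general, since two small steps on two cores in this assay could not reveal a modest dependence on the core and say nothing about other cores.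

From the compounds shown here alone, only methoxy and chloro stand at this place, so it remains open whether an amine, a carboxylic acid or a longer alkoxy chain there would give a step beyond the scatter. Going by these compounds, the two cores differ in more than one place, and what each of those differences contributes also remains open.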